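Compound 4: Pyrrolidinyl in Place of Carbamoylethylamino

The source may hold more compounds than are shown below. What is called first, only, known or untested is meant among the compounds shown, and "the series" means these compounds.

Compound 1 `CC(C)C[C@H](NC(=O)CNC(=O)CC[C@H](NS(=O)(=O)c1ccc(Cl)c(C(F)(F)F)c1)C(=O)O)C(=O)N[C@H](C(=O)N[C@@H](C)C(N)=O)C(C)C` was examined in an assay on isolated protein for inhibition of matrix metalloproteinase-9 (Homo sapiens), read by fluorescence, with a stated time of 15 min; on this read-out higher numbers stand for weaker inhibition and lower numbers for stronger inhibition. In this assay compound 1 gives only a limit, > 100000 nM. Compound 2 `CC(C)C[C@H](NC(=O)CNC(=O)CC[C@H](NS(=O)(=O)c1ccc(Cl)c(C(F)(F)F)c1)C(=O)O)C(=O)N[C@H](C(N)=O)C(C)C` likewise gives only a limit in this assay, > 100000 nM. Compound 3 `O=C(O)[C@H](CCc1ccccc1)NS(=O)(=O)c1ccc(Cl)c(C(F)(F)F)c1` also gives only a limit in this assay, > 100000 nM. The step that the two limits leave unreadable from compound 1 to compound 2 is therefore unreadable, and all three values sit at the same point, (the limit of > 100000 nM in this assay, at which 3 of the 3 values shown sit). Compound 4 `CC(C)C[C@H](NC(=O)CNC(=O)CC[C@H](NS(=O)(=O)c1ccc(Cl)c(C(F)(F)F)c1)C(=O)O)C(=O)N[C@H](C(=O)N1CCC[C@H]1CC(N)=O)C(C)C` differs from compound 1 by 2-(carbamoylmethyl)pyrrolidin-1-yl in place of (1-carbamoylethyl)amino on a carbonyl carbon. Among the compounds with values here, no measured step bears on this change, and compound 1 itself stands at the limit. The step from compound 1 to compound 4 is therefore expected to be a number no higher from compound 1 to compound 4 (the limit leaves the size open), nothing beyond the scatter. Compound 4 is expected to give about 100000 nM in this assay, between 30000 nM and 300000 nM, most probably again only as a limit.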

Compound 4, half-maximal inhibitory concentration: > 100000 nM
Compound 4: a limit, no number; the forecaster's own chance of this, stated with the estimate: 85%; the middle value lies on the limit itself.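

In this assay compound 4 gives only a limit (> 100000 nM), so the steps to it from compound 1 and compound 2 cannot be read. The compounds shown leave open whether any of these changes alters inhibition at all: the limit of > 100000 nM in this assay, at which 4 of the 4 values shown sit.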